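Heteroaryl swap on the sulfur of a cytotoxic anilide series

The compounds below may be only part of what the source reports. "The series", "measured", "known", "first", "only" and "open" are said of these compounds alone.

Compound 1 `Cn1nnnc1SCC(=O)Nc1ccc(-c2nc(-c3ccccc3)c(-c3ccccc3)n2C)cc1`: 77.5%
Compound 2 `Cc1nnc(SCC(=O)Nc2ccc(-c3nc(-c4ccccc4)c(-c4ccccc4)n3C)cc2)s1`: 83.4%

Both values come from a functional assay on MCF7 cells (Homo sapiens) for cytotoxicity, read by MTT assay, with a stated time of 24 h, tested at 32 ug/mL; a lower number here means a weaker effect, a higher number a stronger effect of the compound at the concentration tested. Among the compounds with values here, compound 2 has the higher of the two numbers, but its only neighbour, compound 1, sits a step away that is within the scatter: a number 5.9 percentage points higher from compound 1 to compound 2 (within the scatter). Compound 3 `Cn1ccnc1SCC(=O)Nc1ccc(-c2nc(-c3ccccc3)c(-c3ccccc3)n2C)cc1` has not been measured in this assay; it differs from compound 2 by 1-methyl-1H-imidazol-2-yl in place of 5-methyl-1,3,4-thiadiazol-2-yl on a sulfur. Within the data shown here, the one step that bears on this place, the exchange of one five-membered heteroaryl on the sulfur for another, stayed within the scatter, so no step beyond the scatter is expected: a number 4.4 percentage points lower from compound 2 to compound 3 (within the scatter). Compound 3 is therefore expected to give 79%, between 64% and 92%.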

Compound 3, a percentage reported as activity, at one concentration (the size of the read-out at that concentration, not a potency): 43.4%
For compound 3 the middle estimate is 35.6 percentage points above the measured one, and the stated range ends above it.
By their numbers in this assay, from the lowest: compound 3; then compounds 1 and 2 (each within the scatter of the next).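

In this assay, the heteroaryl on the sulfur proves not to be freely exchangeable: with 1-methyl-1H-imidazol-2-yl there is a number 40 percentage points lower from compound 2 to compound 3 (beyond the scatter), and likewise a number 34.1 percentage points lower from compound 1 to compound 3 (beyond the scatter). The position therefore responds strongly to this change, which the earlier exchange, a number 5.9 percentage points higher from compound 1 to compound 2 (within the scatter), did not reveal. Nothing available explains the difference. On these data alone, it remains open whether a pyridin-2-yl ring or a plain methyl on the sulfur would keep the effect of compound 2 or share the lower number of compound 3.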